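The compounds below may be only part of what the source reports. "The series", "measured", "known", "first", "only" and "open" are said of these compounds alone.

Of the compounds shown here, three that share one core have been measured in an assay for inhibition of protein disulfide-isomerase (Homo sapiens), with a stated time of 1 h; on this read-out lower numbers stand for stronger inhibition and higher numbers for weaker inhibition. Compound 1 `Cc1ccnc(NC(c2ccc(C(F)(F)F)cc2)c2ccc3cccnc3c2O)c1` gives 26500 nM. Compound 2 `Cc1ccnc(NC(c2ccccc2C)c2ccc3cccnc3c2O)c1` reaches only the assay limit, > 40000 nM. Compound 3 `Cc1ccnc(NC(c2cccc(F)c2)c2ccc3cccnc3c2O)c1` gives 350 nM, the lowest of the two numbers shown; the step of a 76-fold lower number from compound 1 to compound 3 (1.88 log units; beyond the scatter) and the step of an at least 110-fold lower number from compound 2 to compound 3 (2.05 log units; beyond the scatter) both set it well apart. Compound 4 `CCc1ccc(C(Nc2cc(C)ccn2)c2ccc3cccnc3c2O)cc1` has not been measured; it differs from compound 3 by 4-ethylphenyl in place of 3-fluorophenyl on a saturated chain carbon bound to an aromatic carbon and a nitrogen on an aromatic ring. The nearest guide is compound 1, which carries a 4-(trifluoromethyl)phenyl at the same place and gives 26500 nM; the step of a 76-fold lower number from compound 1 to compound 3 (1.88 log units; beyond the scatter) shows how much that group cost. A 4-ethylphenyl is therefore expected to weaken inhibition by a large step, a 43-fold higher number from compound 3 to compound 4 (1.63 log units; beyond the scatter). Compound 4 is estimated at 15000 nM, within 3000 nM to 60000 nM.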

Compound 4, half-maximal inhibitory concentration: 5390 nM
Compound 4: the middle estimate sits 2.8-fold (0.44 log units) above what was measured; the range from low to high includes it.
By their numbers in this assay, from the lowest: compound 3; then compound 4; then compound 1. At a limit, above all of these: compound 2.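

With a 15-fold higher number from compound 3 to compound 4 (1.19 log units; beyond the scatter), a second group at this place falls well short of 3-fluorophenyl, and a 4.9-fold lower number from compound 1 to compound 4 (0.69 log units; beyond the scatter) shows that ethyl in place of trifluoromethyl wins back only part of that gap. The step of an at least 7.4-fold lower number from compound 2 to compound 4 (0.87 log units; beyond the scatter) is only a floor, set by a limit and not by a number: the limit of > 40000 nM in this assay, at which 1 of the 4 values shown sits.

Going by these compounds, it remains open whether the fluorine itself or where it sits on the ring accounts for the low number of compound 3. A 4-fluorophenyl or a 3-ethylphenyl would separate the two.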